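Pyrimidin-2-yl on the sulfonamide nitrogen of compound 2

A few compounds are considered here, and "the series" means these few. Any claim that something is new, unique, unknown or untested is made for them only; others in the source may bear on it.

Within the data shown here, in an ADME assay on the whole organism (Mus musculus, strain BALB/c), read by LC-MS, with a stated time of 24 h, at a dose of 1 mg/kg by the intravenous route (on this read-out higher numbers stand for higher exposure at the dose given and lower numbers for lower exposure), only two compounds have numbers so far, and compound 2 (`Cn1nccc1-c1cc(C(F)(F)F)ccc1[C@H]1CCOc2cc(S(=O)(=O)Nc3nccs3)ccc21`) is the lower of them at 1150 ng.h/mL on this read-out. Compound 1 (`O=S(=O)(Nc1ncccn1)c1ccc2c(c1)OCC[C@@H]2c1ccc(C(F)(F)F)cc1-c1ccc(F)nc1`) gives 6370 ng.h/mL in this assay and so stands higher, by a gap beyond the scatter.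

Compound 3 (`Cn1nccc1-c1cc(C(F)(F)F)ccc1[C@H]1CCOc2cc(S(=O)(=O)Nc3ncccn3)ccc21`) is compound 2 with one change: pyrimidin-2-yl in place of 1,3-thiazol-2-yl on a sulfonamide nitrogen. Among the measured compounds shown here, no measured pair shows this change on its own. For the measured compounds named here, the only guide is compound 1 at 6370 ng.h/mL which also bears pyrimidin-2-yl on a sulfonamide nitrogen. It differs from compound 2 in a further place as well, so only part of the gap between the two is expected to carry over. A rise is expected in this assay, estimated as a 2.3-fold higher number from compound 2 to compound 3 (0.35 log units; beyond the scatter) and thus a modest step that may only just clear the scatter. On this reasoning, compound 3 is expected at 2600 ng.h/mL (estimated range 1100 ng.h/mL to 6000 ng.h/mL).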

Compound 3, area under the concentration-time curve: 6190 ng.h/mL
Compound 3: middle estimate off by 2.4-fold (0.38 log units), on the low side; the whole stated range lies below it.
By their numbers in this assay, from the lowest: compound 2; then compounds 3 and 1 (each within the scatter of the next).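

In this assay, pyrimidin-2-yl in place of 1,3-thiazol-2-yl on a sulfonamide nitrogen can now be read as a single change, and it gives a 5.4-fold higher number from compound 2 to compound 3 (0.73 log units; beyond the scatter), so this position alone accounts for a step beyond the scatter. The other single change, 1-methyl-1H-pyrazol-5-yl in place of 6-fluoropyridin-3-yl on an aromatic carbon, gives a 1.0-fold lower number from compound 1 to compound 3 (0.01 log units; within the scatter), which lies within the scatter, so with pyrimidin-2-yl on the sulfonamide nitrogen these two groups are not told apart on this read-out. Nothing shown here explains the step at the sulfonamide nitrogen.

The series shown holds just two groups on the sulfonamide nitrogen, so it remains open whether another ring such as pyridin-2-yl or a simple methyl group would stand with pyrimidin-2-yl or with 1,3-thiazol-2-yl. Also open is whether the step carries over to compounds with 6-fluoropyridin-3-yl on the aromatic carbon, since the compounds shown pair 1,3-thiazol-2-yl only with 1-methyl-1H-pyrazol-5-yl.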